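The source may report more compounds than this note shows. Statements on the series, on what has been measured and on what is new or still open speak of the compounds shown alone.

Measured so far:
- compound 1, `CC(C)(C)c1cc(C(=O)Nc2cccc(CN)c2)n(Cc2ccccc2)n1`: 25 ug/mL
- compound 2, `NCc1csc(NC(=O)c2cc3ccccc3o2)n1`: 50 ug/mL

Both numbers come from a physicochemical assay for solubility, read by nephelometry, measured as kinetic solubility, at pH 6.5; on this read-out lower numbers stand for lower solubility and higher numbers for higher solubility. Compound 1 stands lowest of the two; its nearest neighbour, compound 2, gives a number that differs from it only within the usual scatter, so on this read-out the two cannot be told apart. No single structural change links these two compounds, so their values show only that both lie in the same region.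

Compound 3, `CNCc1csc(NC(=O)c2cc(C(C)(C)C)nn2Cc2ccccc2)n1`, has not yet been measured in this assay. It differs from compound 1 in one place: 4-((methylamino)methyl)-1,3-thiazol-2-yl in place of 3-(aminomethyl)phenyl on an amide-type nitrogen. For the measured compounds named here, no measured pair shows what such a change does, so for compound 3 the expected step is a 1.2-fold higher number from compound 1 to compound 3 (0.08 log units; within the scatter), none beyond the scatter. Compound 3 is therefore estimated to give 30 ug/mL, with a range from 10 ug/mL to 90 ug/mL.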

Compound 3, solubility: 12.5 ug/mL
Compound 3: the middle estimate sits 2.4-fold (0.38 log units) above what was measured; the range from low to high includes it.
By their numbers in this assay, from the lowest: compounds 3, 1 and 2 (each within the scatter of the next, the first and the last beyond it).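

For the compounds shown here, this is the first comparison in this assay between two compounds that differ in one place: with 4-((methylamino)methyl)-1,3-thiazol-2-yl in place of 3-(aminomethyl)phenyl on the amide-type nitrogen, the result is a 2.0-fold lower number from compound 1 to compound 3 (0.30 log units; within the scatter), so this read-out cannot tell the two compounds apart. At this position, then, a benzene ring of carbon only can give way to a five-membered ring holding nitrogen and sulfur, with a methyl added on the amine, without a step beyond the scatter. Nothing measured here explains this result.

On these data alone, since the ring and the methyl on the amine change together, their separate contributions remain unknown. As far as these compounds go, it also remains open what a carboxylic acid or a longer chain would give in place of the methylamino part.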